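Fluoro for trifluoromethyl on the fused ring of compound 3

The source may hold more compounds than are shown below. What is called first, only, known or untested is meant among the compounds shown, and "the series" means these compounds.

Measured so far:
compound 1, `CCC(Nc1nnc(-c2ccc(OC)cc2)o1)[C@H]1CC[C@@H](c2ccnc3c(F)cc(F)cc32)CC1`: 3 nM
compound 2, `COCC(Nc1nnc(-c2ccc(OC)cc2)o1)[C@H]1CC[C@@H](c2ccnc3ccc(F)cc32)CC1`: 3 nM
compound 3, `CCC(Nc1nnc(-c2ccc(OC)cc2)o1)[C@H]1CC[C@@H](c2ccnc3ccc(C(F)(F)F)cc32)CC1`: 3 nM

In an assay on tissue (HeLa cells) for inhibition of Indoleamine 2,3-dioxygenase 1 (Homo sapiens), read by fluorescence, with a stated time of 18 h (a higher number here means a weaker inhibitor, a lower number a stronger inhibitor), compound 3 gives 3 nM. On the digits shown it stands level with compound 1 and compound 2, both of which also give a low single-digit value in this assay, and no gap between any two of the three is beyond the scatter. Compound 4, `CCC(Nc1nnc(-c2ccc(OC)cc2)o1)[C@H]1CC[C@@H](c2ccnc3ccc(F)cc32)CC1`, has not been measured. It differs from compound 3 in one place: fluoro in place of trifluoromethyl on an aromatic carbon. Compound 2 already carries a fluoro on an aromatic carbon of its fused ring system and in this assay compound 2 gives 3 nM, so the data give no sign that a fluoro there costs anything against a trifluoromethyl. Going by the values given here, with no measured step of this kind to lean on, the step is expected to be no change at the digits printed from compound 3 to compound 4 (within the scatter), that is, none beyond the scatter. Compound 4 is therefore expected to give about 3 nM in this assay, within a range of 1.5 nM to 7 nM.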

Compound 4, half-maximal inhibitory concentration: 6 nM
The estimate for compound 4 lay 2.0-fold (0.30 log units) below the measured number, within the range that was stated.
By their numbers in this assay, from the lowest: compounds 1, 2, 3 and 4 (each within the scatter of the next).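

In this assay, fluoro in place of trifluoromethyl on this aromatic carbon gives a 2.0-fold higher number from compound 3 to compound 4 (0.30 log units; within the scatter) and so shows that the position can carry one heavy atom instead of four without a step beyond the scatter. The two other single-place comparisons read alike, with methyl in place of methoxy on the saturated chain carbon giving a 2.0-fold higher number from compound 2 to compound 4 (0.30 log units; within the scatter) and hydrogen in place of fluoro on an aromatic carbon giving a 2.0-fold higher number from compound 1 to compound 4 (0.30 log units; within the scatter) in the same assay. Nothing available here bears on the reason for these results.

Since every step lies within the scatter, the compounds shown do not rank these groups. They also leave open what hydrogen, an amine or a carboxylic acid on this aromatic carbon would give.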